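The compounds below may be only part of what the source reports. "The series", "measured", "known", "first", "only" and "open" are said of these compounds alone.

Compound 1, with structure `COC(C)(C)[C@@H](O)C(=O)N1N=CC[C@H]1C(=O)NCc1cc(Cl)ccc1-n1cnnn1`, was characterised in an ADME assay on liver for metabolic stability, with Liver microsome (Homo sapiens) as the target, read by LC-MS, using microsomes; on this read-out lower numbers stand for slow clearance and higher numbers for fast clearance. In this assay compound 1 gives < 12 mL.min-1.g-1, a value that is a limit of the assay rather than a number. A second compound, compound 2 with structure `CC(C)(C)C[C@@H](O)C(=O)N1OCC[C@H]1C(=O)NCc1cc(Cl)ccc1-n1cnnn1`, carries a different core and a different side chain, and in this assay compound 2 gives < 12 mL.min-1.g-1, again a limit of the assay. Going by the values given here, compound 1 therefore stands at the limit of < 12 mL.min-1.g-1 in this assay, at which 2 of the 2 values shown sit, so no measured step can be placed on it.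

The unmeasured compound 3, with structure `CC(C)(C)[C@@H](O)C(=O)N1N=CC[C@H]1C(=O)NCc1cc(Cl)ccc1-n1cnnn1`, differs from compound 1 by methyl in place of methoxy on a saturated chain carbon bound to three saturated chain carbons. The change is small: a single methyl in place of a methoxy, so that the side chain reads tert-butyl instead of 1-methoxy-1-methylethyl.

No measured step connects the two compounds, and nothing shown speaks for a change beyond the scatter. Compound 3 is therefore expected to stay slow, with an estimated step that the limit leaves unreadable from compound 1 to compound 3 from compound 1. The expected value for compound 3 in this assay is 10 mL.min-1.g-1, with a range from 4 mL.min-1.g-1 to 25 mL.min-1.g-1.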

Compound 3, intrinsic clearance in microsomes: < 12 mL.min-1.g-1
Compound 3: a limit, no number; the forecaster's own chance of this, stated with the estimate: 55%; the middle value lies beyond the limit too.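

In this assay compound 3 gives < 12 mL.min-1.g-1, which is a limit of the assay. No step can be read between compound 1 and compound 3, because both sit at the same limit: the limit of < 12 mL.min-1.g-1 in this assay, at which 3 of the 3 values shown sit.

The compounds shown leave open whether methyl in place of methoxy changes the clearance at all.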